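A few compounds are considered here, and "the series" means these few. Any claim that something is new, unique, unknown or untested is made for them only; others in the source may bear on it.

Working notes on the series. The shared core of compound 1 `N[C@@H]1CCc2ccccc2N(Cc2ccc(-c3ccccc3-c3nn[nH]n3)cc2)C1=O` carries a free amine; in a functional assay on cells (Pituitary gland cell) with growth hormone secretagogue receptor type 1 (Rattus norvegicus) as the target (a higher number here means that more compound is needed for the effect, a lower number that less compound is needed), compound 1 gives 9 uM. Compound 2 `C[C@@H](N)C(=O)N[C@@H]1CCc2ccccc2N(Cc2ccc(-c3ccccc3-c3nn[nH]n3)cc2)C1=O` bears an alanyl group on that nitrogen and in this assay compound 2 gives 0.1 uM; 1.4 uM (2 entries), two entries that sit apart from each other. Compound 3 `CC(C)(N)C(=O)N[C@@H]1CCc2ccccc2N(Cc2ccc(-c3ccccc3-c3nn[nH]n3)cc2)C1=O` carries the (1-amino-1-methylethyl)carbonyl group in the same place and in this assay compound 3 gives 0.03 uM, the lowest of the two single numbers here; the step of a 300-fold lower number from compound 1 to compound 3 (2.48 log units; beyond the scatter) is large. The spread of the several entries of compound 2 in this assay, 0.1 uM; 1.4 uM (2 entries) shows how far repeated entries of one compound can lie apart.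

Compound 4 `CC(C)(CN)C(=O)N[C@@H]1CCc2ccccc2N(Cc2ccc(-c3ccccc3-c3nn[nH]n3)cc2)C1=O` differs from compound 3 by aminomethyl in place of amino on a saturated chain carbon bound to a carbonyl carbon and two saturated chain carbons. Going by the values given here, no measured step follows this change; the only step known, a 300-fold lower number from compound 1 to compound 3 (2.48 log units; beyond the scatter), concerns the whole acyl group and not the placing of the amine within it. For compound 4 the change is expected to move the number upward by a moderate amount, as the estimated step of a 10-fold higher number from compound 3 to compound 4 (1.00 log units; beyond the scatter) shows. This expected step remains smaller than the measured step of a 300-fold lower number from compound 1 to compound 3 (2.48 log units; beyond the scatter). For compound 4 the expected value in this assay is 0.3 uM, with a range from 0.05 uM to 2 uM.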

Compound 4, concentration for half-maximal effect: 3 uM
The estimate for compound 4 lay 10-fold (1.00 log units) below the measured number, and the stated range ends below it.
By their numbers in this assay, from the lowest: compound 3; then compound 4; then compound 1.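

In this assay, going by these compounds alone, the change from amino to aminomethyl on this saturated chain carbon gives a 100-fold higher number from compound 3 to compound 4 (2.00 log units; beyond the scatter) and so shows that the number depends strongly on where the amine stands within the acyl group, which the earlier compounds did not show. The acyl group of compound 4 still leaves a 3.0-fold lower number from compound 1 to compound 4 (0.48 log units; beyond the scatter), so only a modest part of the large step to compound 3 remains with this group. Both steps rest on single entries for compound 3 and compound 4, and repeated entries of one compound can lie apart: the several entries of compound 2 in this assay, 0.1 uM; 1.4 uM (2 entries).

The compounds shown cannot separate the added chain carbon from the new place of the amine. On these data alone, how a hydroxymethyl group, a methylamino group or a longer aminoalkyl chain on this carbon would read remains open.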